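Swapping pyridin-3-yl for furan-2-yl on a carbonyl carbon

The compounds below may be only part of what the source reports. "The series", "measured", "known", "first", "only" and "open" are said of these compounds alone.

In an ADME assay on HepG2 2.2.15 cells (Homo sapiens) for cytotoxicity, read by MTT assay (on this read-out lower numbers stand for higher toxicity in this test and higher numbers for lower toxicity in this test), compound 3 `C=C1CC[C@@H]2[C@](C)(CO)[C@H](OC(=O)c3cccnc3)CC[C@@]2(C)[C@@H]1C/C=C1\C=COC1=O` gives 337000 nM. Compound 2 `C=C1CC[C@@H]2[C@](C)(CO)[C@H](OC(=O)/C=C/c3ccccc3)CC[C@@]2(C)[C@@H]1C/C=C1\C=COC1=O` gives 179000 nM, and these two values lie within the usual scatter of each other. Compound 1 `C=C1CC[C@@H]2[C@](C)(COC(=O)/C=C/c3cccc(OC)c3)[C@H](O)CC[C@@]2(C)[C@@H]1/C=C/C1=CCOC1=O` gives > 1970000 nM, which is a limit of the assay and not a number, so it cannot be used to size a step.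

Compound 4 `C=C1CC[C@@H]2[C@](C)(CO)[C@H](OC(=O)c3ccco3)CC[C@@]2(C)[C@@H]1C/C=C1\C=COC1=O` has furan-2-yl in place of pyridin-3-yl on a carbonyl carbon. The rest of the molecule stays the same.

For the measured compounds named here, only one measured step bears on this change. It is the exchange of 2-phenylethenyl for pyridin-3-yl at that same place, a 1.9-fold higher number from compound 2 to compound 3 (0.27 log units; within the scatter). That exchange stayed within the scatter, so no step beyond the scatter is expected here, although a single step is thin support. The expected change is a 1.2-fold lower number from compound 3 to compound 4 (0.07 log units; within the scatter).

For compound 4 the estimated value in this assay is 290000 nM, with an expected range of 130000 nM to 650000 nM.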

Compound 4, half-maximal cytotoxic concentration: 42000 nM
The estimate for compound 4 lay 6.9-fold (0.84 log units) above the measured number; the whole stated range lies above it.
By their numbers in this assay, from the lowest: compound 4; then compounds 2 and 3 (each within the scatter of the next). At a limit, above all of these: compound 1.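

The earlier pair left the impression that the group on this carbonyl carbon hardly matters in this assay, but furan-2-yl gives an 8.0-fold lower number from compound 3 to compound 4 (0.90 log units; beyond the scatter) and also a 4.3-fold lower number from compound 2 to compound 4 (0.63 log units; beyond the scatter), so this place does respond to the group it carries. Both steps lie beyond the scatter and point towards higher toxicity in this test, and the first of them needs only a five-membered aromatic ring in place of a six-membered one. Nothing shown here gives a reason for this shift.

As far as these compounds go, whether the shift is particular to furan-2-yl stays open, and thiophen-2-yl or a plain phenyl on this carbonyl carbon would help to settle that. So does the effect of a group of a different kind here, such as an amine or a carboxylic acid.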